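A few compounds are considered here, and "the series" means these few. Any claim that something is new, unique, unknown or untested is made for them only; others in the source may bear on it.

Measured so far:
compound 1, `CC1(C)C(=O)N(c2ccc(Cl)cc2Cl)c2ncccc21`, 8%
compound 2, `CC1(Sc2ccccc2)C(=O)N(c2ccccc2)c2ncccc21`, 0%
compound 3, `CC1(C)C(=O)N(c2ccc(S(C)(=O)=O)cc2)c2ncccc21`, 0%

All three were tested in a functional assay on the whole organism (Pleural cavity) for inhibition, with Rattus norvegicus as the target, at a dose of 25 mg/kg; on this read-out higher numbers stand for more inhibition at the one dose given (going by the name of the read-out) and lower numbers for less inhibition. Compound 2 stands level with compound 3 at the digits shown, and the two together are the lowest of the three numbers; compound 1 lies only a little higher, and that gap stays within the scatter, so none of the three can be ranked against the others. In short, nothing in this set shows inhibition that rises clearly above the noise of the read-out.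

The next compound, compound 4 `CC1(F)C(=O)N(c2ccccc2)c2ncccc21`, differs from compound 2 in one place: fluoro in place of phenylsulfanyl on a saturated ring carbon. Compound 1 and compound 3 both carry a small group, methyl, on a saturated ring carbon in place of the phenylsulfanyl of compound 2, and their readings in this assay sit no higher than that of compound 2 beyond the scatter. For the measured compounds named here, with no step between measured compounds to draw on, the account of this change can only note that swapping a small group onto that carbon has not lifted the read-out elsewhere in the set. The step from compound 2 to compound 4 is therefore expected to be none beyond the scatter, as a number 4 percentage points higher from compound 2 to compound 4 (within the scatter) expresses. Compound 4 is estimated at 4%, within a range from 0% to 18%.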

Compound 4, a percentage reported as inhibition, in the whole organism at one dose (the size of the read-out at that dose, not a potency): 35%
Estimate against measurement, compound 4: 31 percentage points below; measured number above the stated range.
By their numbers in this assay, from the lowest: compounds 2, 3 and 1 (each within the scatter of the next); then compound 4.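

In this assay, for the compounds shown here, replacing phenylsulfanyl with fluoro on a saturated ring carbon, two ring bonds from the ring nitrogen, gives a number 35 percentage points higher from compound 2 to compound 4 (beyond the scatter), the first step in this set and one that lies clearly beyond the scatter. Going by these compounds alone, it shows that this position is not silent: at the one dose given, the group on that carbon can separate a compound with no measurable inhibition from one with a clear reading, something the earlier compounds, with no step between them, could not show. No measured property is at hand to explain the rise, so the data cannot tell whether it reflects the arrival of fluoro, the departure of phenylsulfanyl, or both.

The compounds shown leave open whether another small group on that carbon, such as a hydroxyl, a methoxy or an amine, would give a reading like that of compound 4 or a different one. They also leave open whether fluoro at this position would give a similar reading if the phenyl group carried a chloro or a methylsulfonyl group.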